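The compounds below may be only part of what the source reports. "The series", "measured", "known", "first", "only" and "open" are said of these compounds alone.

In a functional assay on K562 cells (Homo sapiens) for cytotoxicity, read by trypan blue exclusion, with a stated time of 96 h (on this read-out lower numbers stand for stronger inhibition and higher numbers for weaker inhibition), compound 1 (`COc1cc(OC)c(/C=C/S(=O)(=O)Nc2ccc(OC)c(N)c2)c(OC)c1`) gives 3 nM, compound 2 (`COC(=O)C(C)Nc1cc(NS(=O)(=O)/C=C/c2c(OC)cc(OC)cc2OC)ccc1OC`) gives 300 nM and compound 3 (`COC(=O)C(Nc1cc(NS(=O)(=O)/C=C/c2c(OC)cc(OC)cc2OC)ccc1OC)c1ccc(F)cc1`) gives 2500 nM as the highest of the three numbers, with its steps to both others beyond the scatter. Compound 4 (`COC(=O)C(Nc1cc(NS(=O)(=O)/C=C/c2c(OC)cc(OC)cc2OC)ccc1OC)c1ccc(Br)cc1`) differs from compound 3 by a single exchange (bromo in place of fluoro on an aromatic carbon), bromo in place of fluoro on an aromatic carbon, para to a large group. For the measured compounds named here, no measured step exchanges one halogen for another. The nearest evidence is the modest step (an 8.3-fold higher number from compound 2 to compound 3 (0.92 log units; beyond the scatter)), with 4-fluorophenyl in place of methyl. The large steps (a 100-fold higher number from compound 1 to compound 2 (2.00 log units; beyond the scatter) and an 830-fold higher number from compound 1 to compound 3 (2.92 log units; beyond the scatter)) put a whole side group in place of hydrogen on a nitrogen, so they bear only weakly on this exchange. In this assay no step beyond the scatter is therefore expected, in either direction. The estimated step (no change at the digits printed from compound 3 to compound 4 (within the scatter)) is expected to stay within the scatter. For compound 4 the estimated value is 2500 nM (expected range 800 nM to 8000 nM).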

Compound 4, half-maximal inhibitory concentration: 1000 nM
Compound 4: middle estimate off by 2.5-fold (0.40 log units), on the high side, within the range that was stated.
By their numbers in this assay, from the lowest: compound 1; then compound 2; then compound 4; then compound 3.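

In this assay the halogen on this aromatic carbon, para to a large group, is not silent: a 2.5-fold lower number from compound 3 to compound 4 (0.40 log units; beyond the scatter) follows from bromo in place of fluoro, a modest step from one heavy atom exchanged for another. The 4-bromophenyl side group still stands on the weak side of methyl, with a 3.3-fold higher number from compound 2 to compound 4 (0.52 log units; beyond the scatter) on that exchange, and of hydrogen on the nitrogen, with a 330-fold higher number from compound 1 to compound 4 (2.52 log units; beyond the scatter) for the whole side group, so the halogen exchange recovers only a small part of what substitution on that nitrogen loses. Nothing available explains the difference between bromo and fluoro here.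

As far as these compounds go, whether chloro or iodo on the same carbon would fall in line with bromo and fluoro remains open. Also open, from the compounds shown here alone, is how a carboxylic acid in place of the methoxycarbonyl group would read in this assay on the 4-bromophenyl side group.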